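A trifluoromethyl swap at the assay limit

The compounds below may be only part of what the source reports. "The series", "measured", "known", "first", "only" and "open" are said of these compounds alone.

In a functional assay on SEM cells (Homo sapiens) for cytotoxicity, with a stated time of 72 h (on this read-out lower numbers stand for an effect already at smaller amounts and higher numbers for an effect only at larger amounts of compound), compound 1 (`C=C[C@@](C)(/C=C/c1ccc(Nc2ccccc2)cc1)CCC=C(C)C`) gives only a limit (> 36600 nM). Compound 2 (`C=C[C@@](C)(/C=C/c1ccc(Nc2ccc(F)cc2)cc1)CCC=C(C)C`) also gives only a limit (> 36600 nM). Compound 3 (`C=C[C@@](C)(/C=C/c1ccc(Nc2ccc(Cl)cc2)cc1)CCC=C(C)C`) likewise stands at a limit (> 36600 nM). Among the measured compounds shown here, the series so far shows the limit of > 36600 nM in this assay, at which 3 of the 3 values shown sit, and no number. Compound 4 (`C=C[C@@](C)(/C=C/c1ccc(Nc2ccc(C(F)(F)F)cc2)cc1)CCC=C(C)C`) differs from compound 3 by trifluoromethyl in place of chloro on an aromatic carbon in the form of trifluoromethyl in place of chloro on an aromatic carbon. For the measured compounds named here, the steps that bear on it are a step that the two limits leave unreadable from compound 1 to compound 2 and a step that the two limits leave unreadable from compound 1 to compound 3 and a step that the two limits leave unreadable from compound 2 to compound 3 so none offers a size to carry over. No step beyond the scatter, in either direction, is therefore expected in this assay and another limit is likely. The estimate amounts to a number no higher from compound 3 to compound 4 (the limit leaves the size open) as the expected step. For compound 4 the estimated value is 36600 nM with an expected range from 15000 nM to 60000 nM in this estimate.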

Compound 4, half-maximal effective concentration: > 36600 nM
Compound 4: a limit, no number; the forecaster's own chance of this, stated with the estimate: 80%; the middle value sits exactly at the limit.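

No step from compound 1, compound 2 or compound 3 to compound 4 can be read, and the series remains at a single limit: the limit of > 36600 nM in this assay, at which 4 of the 4 values shown sit.

The compounds shown leave open whether hydrogen, fluoro, chloro and trifluoromethyl differ at all in this assay.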